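The source may hold more compounds than are shown below. What is called first, only, known or untested is meant among the compounds shown, and "the series" means these compounds.

Compound 1 `CC1SC(c2cccc(C(=O)NCCCCc3ccccc3)c2)N(c2ccc(C3CC3)cc2)C1=O` gives 191 nM in a functional assay on HOS-TE85 cells (Homo sapiens) for inhibition, read by CCK-8 assay, with a stated time of 72 h; a higher number here means a weaker inhibitor, a lower number a stronger inhibitor.
Compound 2 `COc1ccc(F)cc1N1C(=O)CSC1c1cccc(C(=O)NCCCCn2cccn2)c1` gives 97.3 nM in this assay.
Compound 3 `CCN(CC)c1ccc(N2C(=O)CSC2c2cccc(C(=O)NCCCCc3ccccc3)c2)cc1` gives only a limit of the assay in this assay, namely > 1000 nM.

Among the two numbers, compound 2 has the lowest one, and the nearest number, that of compound 1, lies within the usual scatter, so no order between compound 1 and compound 2 can be claimed. Compound 4 `O=C(NCCCCn1cccn1)c1cccc(C2SCC(=O)N2c2ccncc2)c1` differs from compound 2 in one place: pyridin-4-yl in place of 5-fluoro-2-methoxyphenyl on an amide-type nitrogen in a ring. Among the compounds with values here, no measured pair shows this change, so no comparable step exists. Given that the numbers in hand vary with the group on the amide-type nitrogen in a ring, a modest weakening in this assay is expected, as the step of a 2.6-fold higher number from compound 2 to compound 4 (0.41 log units; beyond the scatter) expresses. Compound 4 is therefore estimated at 250 nM, within a range from 80 nM to 1000 nM.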

Compound 4, half-maximal inhibitory concentration: > 1000 nM
Compound 4: only a limit was reported; the forecaster's own chance of this, stated with the estimate: 15%; middle value at least 4.0-fold (0.60 log units) away from the limit.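

Putting pyridin-4-yl in place of 5-fluoro-2-methoxyphenyl on the amide-type nitrogen in the ring is costly in this assay, with an at least 10-fold higher number from compound 2 to compound 4 (1.01 log units; beyond the scatter). Within the data shown here, this single-place pair shows that the group at this position can matter strongly while the rest of the molecule stays unchanged, which the earlier compounds could not show. For compound 4, the reading is a limit of the assay and not a number: the limit of > 1000 nM in this assay, at which 2 of the 4 values shown sit.

The pair does not tell which part of the change matters. A plain phenyl or a methoxyphenyl without the fluorine at this position could begin to separate these parts.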